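The source may hold more compounds than are shown below. What is called first, only, known or untested is meant among the compounds shown, and "the series" means these compounds.

Compound 1 `O=C(Nc1ccccc1)c1c(-c2ccccc2)c(-c2ccccc2)nn1-c1ccccc1` and compound 2 `O=C(Nc1ccccc1)c1c(-c2ccc(Cl)cc2)c(-c2ccccc2)nn1-c1ccccc1` share one core and differ only by chloro in place of hydrogen on an aromatic carbon. In a functional assay on Caco-2 cells (Homo sapiens) for cytotoxicity, with a stated time of 24 h (a higher number here means a weaker inhibitor, a lower number a stronger inhibitor), compound 1 gives 1.68 ug/mL, and compound 2 gives 1.74 ug/mL; the step of a 1.0-fold higher number from compound 1 to compound 2 (0.02 log units; within the scatter) is within the scatter. For the measured compounds named here, compound 1 therefore stands at the lowest of the two numbers so far, with compound 2 within the scatter of it, so the two cannot be told apart.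

Compound 3 `Cc1ccc(NC(=O)c2c(-c3ccccc3)c(-c3ccccc3)nn2-c2ccccc2)cc1` differs from compound 1 by methyl in place of hydrogen on an aromatic carbon. Going by the values given here, the one measured step that bears on a single-atom change to an aromatic ring of this core, a 1.0-fold higher number from compound 1 to compound 2 (0.02 log units; within the scatter), concerns a chloro rather than a methyl and stayed within the scatter; no measured step touches the phenylcarbamoyl ring itself. On that thin basis, no step beyond the scatter is expected in this assay for this change. For compound 3 the expected value is 1.7 ug/mL, with a range from 0.9 ug/mL to 3.4 ug/mL, which amounts to an expected step of a 1.0-fold higher number from compound 1 to compound 3 (0.01 log units; within the scatter).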

Compound 3, half-maximal inhibitory concentration: 2.21 ug/mL
The estimate for compound 3 lay 1.3-fold (0.11 log units) below the measured number; low and high end bracket the measured number.
By their numbers in this assay, from the lowest: compounds 1, 2 and 3 (each within the scatter of the next).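

In this assay, methyl in place of hydrogen on an aromatic carbon of the phenylcarbamoyl ring, para to a large group, gives a 1.3-fold higher number from compound 1 to compound 3 (0.12 log units; within the scatter). For the compounds shown here, this is the first measured step on that ring, and it shows that phenyl to 4-methylphenyl at this place does not move the number beyond the scatter, though the reading rests on this single pair. No measured evidence bears on this result.

From the compounds shown here alone, it remains open whether an amine, a carboxylic acid or a longer chain such as butyl at the same place on the phenylcarbamoyl ring would give a step beyond the scatter. Going by these compounds, the effect of a methyl on the other carbons of that ring also remains open.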